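Benzyl ether replacement at the aryloxy chain of the shared core

The source may report more compounds than this note shows. Statements on the series, on what has been measured and on what is new or still open speak of the compounds shown alone.

Measured:
compound 1 `C=CCOc1ccc2c(=O)c(-c3cc(OC)c(OC)cc3OC)coc2c1`: 4750 nM
compound 2 `C#CCOc1ccc2c(=O)c(-c3cc(OC)c(OC)cc3OC)coc2c1`: 3680 nM
compound 3 `COc1cc(OC)c(-c2coc3cc(OCc4cccc(F)c4)ccc3c2=O)cc1OC`: 1300 nM

In a functional assay on A-375 cells (Homo sapiens) for antiproliferative activity, read by MTT assay, with a stated time of 24 h (on this read-out higher numbers stand for weaker inhibition and lower numbers for stronger inhibition), compound 1 gives the highest number of the three. The step of a 1.3-fold lower number from compound 1 to compound 2 (0.11 log units; within the scatter) is within the scatter, whereas a 3.7-fold lower number from compound 1 to compound 3 (0.56 log units; beyond the scatter) and a 2.8-fold lower number from compound 2 to compound 3 (0.45 log units; beyond the scatter) are modest and beyond it, so an aryl group on the saturated chain carbon bound to the ring oxygen has so far brought lower numbers than vinyl or ethynyl.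

Compound 4 `COc1cc(OC)c(-c2coc3cc(OCc4ccc(C(F)(F)F)cc4)ccc3c2=O)cc1OC` differs from compound 1 by 4-(trifluoromethyl)phenyl in place of vinyl on a saturated chain carbon bound to an oxygen on an aromatic ring. Among the compounds with values here, the only step bearing on this is the one from compound 1 to compound 3, another aryl in place of vinyl, and a drop of comparable size is therefore expected, as a 3.2-fold lower number from compound 1 to compound 4 (0.50 log units; beyond the scatter). For compound 4 the expected value is 1500 nM, within 500 nM to 4500 nM.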

Compound 4, half-maximal inhibitory concentration: 2280 nM
Compound 4: middle estimate off by 1.5-fold (0.18 log units), on the low side, and the stated range covers the measured number.
By their numbers in this assay, from the lowest: compounds 3, 4, 2 and 1 (each within the scatter of the next, the first and the last beyond it).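

In this assay a second aryl group on the saturated chain carbon also gives a lower number than vinyl (a 2.1-fold lower number from compound 1 to compound 4 (0.32 log units; beyond the scatter)), so this gain is not confined to 3-fluorophenyl. The two aryl groups cannot be told apart (a 1.8-fold higher number from compound 3 to compound 4 (0.24 log units; within the scatter)), and 4-(trifluoromethyl)phenyl does not separate from ethynyl (a 1.6-fold lower number from compound 2 to compound 4 (0.21 log units; within the scatter)), unlike 3-fluorophenyl. No evidence is available to explain these differences.

Still open, from the compounds shown here alone, is how unsubstituted phenyl, or an amine or carboxylic acid on the aryl ring, would read here. A longer chain carrying the aryl group also remains untested in the compounds shown.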